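Moving the methoxy group on the benzyl substituent

A few compounds are considered here, and "the series" means these few. Any claim that something is new, unique, unknown or untested is made for them only; others in the source may bear on it.

Compound 2 `COc1cccc(Cc2cnc(CCc3ccc(-c4ccccc4C(=O)O)cc3)[nH]2)c1` gives 79 nM in an in vitro functional assay on cells for agonist activity at Bombesin receptor subtype-3 (Mus musculus), read by luminescence and calcium flux (on this read-out lower numbers stand for an effect already at smaller amounts and higher numbers for an effect only at larger amounts of compound), the second highest of the three numbers measured; compound 3 `O=C(O)c1ccccc1-c1ccc(CCc2ncc(Cc3ccc(Cl)cc3)[nH]2)cc1` gives 102 nM, and compound 1 `Cc1ccccc1Cc1cnc(CCc2ccc(-c3ccccc3C(=O)O)cc2)[nH]1` gives 9.3 nM. The step of a 1.3-fold higher number from compound 2 to compound 3 (0.11 log units; within the scatter) lies within the scatter, whereas an 8.5-fold higher number from compound 1 to compound 2 (0.93 log units; beyond the scatter) and an 11-fold higher number from compound 1 to compound 3 (1.04 log units; beyond the scatter) set the 2-methylphenyl analogue clearly apart. Compound 4 `COc1ccccc1Cc1cnc(CCc2ccc(-c3ccccc3C(=O)O)cc2)[nH]1` carries 2-methoxyphenyl in place of 3-methoxyphenyl on a saturated chain carbon bound to an aromatic carbon. Among the measured compounds shown here, no measured pair makes exactly this change, but compound 1, the only 2-substituted analogue, shows the lowest number with 9.3 nM. Compound 4 is therefore expected to give a lower number, a step of a 3.6-fold lower number from compound 2 to compound 4 (0.56 log units; beyond the scatter) in this assay. For compound 4 the estimated value is 22 nM, with a range from 6 nM to 70 nM.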

Compound 4, half-maximal effective concentration: 163 nM
Compound 4: middle estimate off by 7.4-fold (0.87 log units), on the low side; measured number above the stated range.
By their numbers in this assay, from the lowest: compound 1; then compounds 2, 3 and 4 (each within the scatter of the next, the first and the last beyond it).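

A 2-methoxyphenyl group does not bring back the low number of compound 1: the change from 3-methoxyphenyl gives a 2.1-fold higher number from compound 2 to compound 4 (0.31 log units; beyond the scatter). The sharper contrast is methoxy in place of methyl on an aromatic carbon, with an 18-fold higher number from compound 1 to compound 4 (1.24 log units; beyond the scatter), so what is attached to that ring carbon matters here, not only where it sits. Compound 1 remains apart from the others, while a 1.6-fold higher number from compound 3 to compound 4 (0.20 log units; within the scatter) stays within the scatter. Going by these compounds, whether a 2-ethylphenyl or 2-chlorophenyl group would track compound 1 or compound 4 remains open. Nothing available explains the gap between methyl and methoxy.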